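The source may hold more compounds than are shown below. What is called first, only, known or untested is meant among the compounds shown, and "the series" means these compounds.

Measured so far in a functional assay on U-87MG ATCC cells for cytotoxicity against U-87 MG (Homo sapiens), read by MTT assay, with a stated time of 72 h; a higher number here means a weaker inhibitor, a lower number a stronger inhibitor:
- compound 1 `COc1ncc(-c2ccc3nc(NC(=O)N4CCCC4)nn3c2)cc1NS(=O)(=O)c1ccc(F)cc1`: 1690 nM
- compound 2 `COc1ncc(-c2ccc3nc(NC(=O)N(C)C)nn3c2)cc1NS(=O)(=O)c1ccc(F)cc1`: 1780 nM
- compound 3 `CCCNC(=O)Nc1nc2ccc(-c3cnc(OC)c(NS(=O)(=O)c4ccc(F)cc4)c3)cn2n1`: 420 nM

Compound 3 holds the lowest number of the three. Compound 4 `COc1ncc(-c2ccc3nc(NC(=O)NCCN4CCN(C)CC4)nn3c2)cc1NS(=O)(=O)c1ccc(F)cc1` differs from it by 4-methylpiperazin-1-yl in place of methyl on a saturated chain carbon, two bonds along the chain from an amide-type nitrogen.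

The relevant steps all change the group on the carbonyl carbon: a 4.0-fold lower number from compound 1 to compound 3 (0.60 log units; beyond the scatter) and a 4.2-fold lower number from compound 2 to compound 3 (0.63 log units; beyond the scatter) are modest, while a 1.1-fold higher number from compound 1 to compound 2 (0.02 log units; within the scatter) is not. For the measured compounds named here, no measured compound carries a 4-methylpiperazin-1-yl group, so the direction is uncertain. A modest rise in this assay is expected, with a 1.4-fold higher number from compound 3 to compound 4 (0.15 log units; within the scatter) as the estimated step. The estimate for compound 4 is 600 nM, with an expected range of 150 nM to 2400 nM.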

Compound 4, half-maximal inhibitory concentration: 760 nM
For compound 4 the middle estimate is 1.3-fold (0.10 log units) below the measured one; the measured number falls inside the stated range.
By their numbers in this assay, from the lowest: compounds 3 and 4 (each within the scatter of the next); then compounds 1 and 2 (each within the scatter of the next).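

In this assay, the methyl on a saturated chain carbon, two bonds along the chain from an amide-type nitrogen, gives way to the far larger 4-methylpiperazin-1-yl with a 1.8-fold higher number from compound 3 to compound 4 (0.26 log units; within the scatter) and no step beyond the scatter. Against the two other groups on the carbonyl carbon, (2-(4-methylpiperazin-1-yl)ethyl)amino gives a 2.3-fold lower number from compound 2 to compound 4 (0.37 log units; beyond the scatter) and a 2.2-fold lower number from compound 1 to compound 4 (0.35 log units; beyond the scatter) as its steps, so the gain seen with propylamino largely survives. Nothing measured here accounts for these steps.

From the compounds shown here alone, whether a morpholine, a primary amine or a carboxylic acid at the chain end would fit equally well stays open, as does the effect of a shorter or longer chain.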